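A few compounds are considered here, and "the series" means these few. Any claim that something is new, unique, unknown or untested is made for them only; others in the source may bear on it.

In a functional assay on IMR-32 cells (Homo sapiens) for inhibition, read by sulforhodamine B assay, with a stated time of 48 h (on this read-out lower numbers stand for stronger inhibition of growth and higher numbers for weaker inhibition of growth), compound 3 `O=C(CCN1C(=O)CSc2ccccc21)N1CCN(c2ccc(F)cc2)CC1` gives 10000 nM, the highest of the two numbers shown. Compound 2 `O=C(CCN1C(=O)CSc2ccccc21)N1CCC(Cc2ccccc2)CC1` gives 100 nM. Compound 1 `CC(C)(C)OC(=O)N1CCN(C(=O)CCN2C(=O)CSc3ccccc32)CC1` sits at > 100000 nM, which is a limit of the assay rather than a number (the limit of > 100000 nM in this assay, at which 1 of the 3 values shown sits). Within the data shown here, the single measured step that changes one place, an at least 10-fold lower number from compound 1 to compound 3 (1.00 log units; beyond the scatter), is at least modest in size. Compound 4 `O=C(CCN1C(=O)CSc2ccccc21)N1CCN(c2ccccc2)CC1` differs from compound 3 by hydrogen in place of fluoro on an aromatic carbon. Among the measured compounds shown here, the measured step swaps the whole group on the ring nitrogen and so does not bear on removing a fluoro; no measured pair tests this change. The step expected, no change at the digits printed from compound 3 to compound 4 (within the scatter), lies within the scatter. Compound 4 is therefore estimated at 10000 nM, with a range from 3000 nM to 30000 nM.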

Compound 4, concentration for 50% growth inhibition: < 10 nM
Compound 4: a limit, no number; the forecaster's own chance of this, stated with the estimate: 10%; middle value at least 1000-fold (3.00 log units) away from the limit.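

In this assay, hydrogen in place of a single fluoro on the aromatic ring gives an at least 1000-fold lower number from compound 3 to compound 4 (3.00 log units; beyond the scatter) and so shows that this one atom matters greatly. Set against the tert-butoxycarbonyl group of compound 1, the plain phenyl group gives an at least 10000-fold lower number from compound 1 to compound 4 (4.00 log units; beyond the scatter) and is the largest step shown here. Compound 4 gives < 10 nM and this is a limit, not a number: (the limit of < 10 nM in this assay, at which 1 of the 4 values shown sits).

As far as these compounds go, how much stronger compound 4 truly is stays open. So does whether chloro, methoxy or an amine at this place would behave like fluoro or like hydrogen.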